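The source may report more compounds than this note shows. Statements on the series, on what has been measured and on what is new or still open speak of the compounds shown alone.

Compound 1 `C=CCOc1cc(OC)c(C(=O)/C=C/c2ccccc2)c(OCC=C)c1` gives 17100 nM.
Compound 2 `C=CCOc1cc(OC)c(C(=O)/C=C/c2cc(OC)c(OC)c(OC)c2)c(OCC=C)c1` gives 40900 nM.
Compound 3 `COc1ccc(/C=C/C(=O)c2c(O)cc(O)cc2OC)cc1` gives "not determined" (no result reported).

In an ADME assay on Vero cells (Chlorocebus sabaeus) for cytotoxicity, read by MTT assay (on this read-out lower numbers stand for stronger inhibition and higher numbers for weaker inhibition), compound 1 gives 17100 nM, the lowest of the two numbers available. Compound 2 gives 40900 nM, a gap that lies beyond the usual scatter, while compound 3 gives "not determined" (no result reported) in this assay. Compound 4 `C=CCOc1cc(OC)c(C(=O)/C=C/c2ccc(Cl)cc2)c(OCC=C)c1` differs from compound 1 by one change: chloro in place of hydrogen on an aromatic carbon.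

Among the measured compounds shown here, no measured pair with this single change is available for comparison, so the size of the step can only be judged from compound 1 itself. A step of modest size toward a lower number is expected, from compound 1 at 17100 nM, shown as a 1.3-fold lower number from compound 1 to compound 4 (0.12 log units; within the scatter). Compound 4 is thus estimated at 13000 nM, within a range of 5000 nM to 40000 nM.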

Compound 4, half-maximal inhibitory concentration: 10400 nM
Beside the measured number, compound 4's estimate is 1.3-fold (0.10 log units) above it; measured number inside the range.
By their numbers in this assay, from the lowest: compounds 4 and 1 (each within the scatter of the next); then compound 2.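

In this assay, chloro in place of hydrogen on an aromatic carbon, para to a large group, gives a 1.6-fold lower number from compound 1 to compound 4 (0.22 log units; within the scatter) and so leaves compound 4 indistinguishable from compound 1 on this read-out. Among the compounds shown here, this is the first single-place comparison, and at this position the change does not separate the two compounds. No independent evidence bears on this result. As far as these compounds go, whether an amine or a carboxylic acid at this same position would give a reading beyond the scatter remains open, as does whether chloro would behave alike on another aromatic carbon of this ring.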